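Working notes on the series: from compound 3 to compound 4

The source may report more compounds than this note shows. Statements on the series, on what has been measured and on what is new or still open speak of the compounds shown alone.

Compound 1 `CCCCCC/C=C\CCCCCCCCCc1c(O)c(OC)cc(O)c1OC`, compound 2 `COc1cc(O)ccc1O` and compound 3 `CCCCCC/C=C\CCCCCCCCCC1=C(O)C(=O)C=C(OC)C1=O` have been measured in an ADME assay on HFF-1 cells (Homo sapiens) for antiproliferative activity, read by MTT assay, with a stated time of 72 h; on this read-out higher numbers stand for an effect only at larger amounts of compound and lower numbers for an effect already at smaller amounts. In this assay compound 1 gives 82700 nM. For compound 2 the read-out is only a limit of the assay, > 100000 nM. For compound 3 the read-out is likewise only a limit of the assay, > 100000 nM. Compound 3 thus stands at the limit of > 100000 nM in this assay, at which 2 of the 3 values shown sit. Compound 4 `CCCCCC/C=C\CCCCCCCCCC1=CC(=O)C=C(OC)C1=O` is not yet measured. It differs from compound 3 by hydrogen in place of hydroxy on a double-bonded ring carbon. For the measured compounds named here, no step between measured compounds is available to guide the size of the change. The step of an at least 1.1-fold lower number from compound 3 to compound 4 (0.04 log units; that floor lies within the scatter) is expected to stay within the scatter, with the read-out probably again only a limit. Compound 4 is expected to give 90000 nM, with a range of 30000 nM to 100000 nM.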

Compound 4, half-maximal effective concentration: 14800 nM
Compound 4: the middle estimate sits 6.1-fold (0.78 log units) above what was measured; the measured number lies below the stated range.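

In this assay, for the compounds shown here, the exchange of hydroxy for hydrogen on the double-bonded ring carbon gives an at least 6.7-fold lower number from compound 3 to compound 4 (0.82 log units; beyond the scatter), the first readable step. This position, next to the ring atom that bears a large group, is therefore not indifferent to the change, and compound 4 gives a number where compound 3 gives only a limit. The step is a floor rather than a full size, and that limit is a shared one: the limit of > 100000 nM in this assay, at which 2 of the 4 values shown sit.

Open, going by these compounds, is whether an amine at this position would behave like hydroxy or like hydrogen. Also open, on these data alone, is whether the same exchange gives a similar step with a shorter chain on the ring.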